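Compound 3 to compound 4: one more methoxy

The compounds below may be only part of what the source reports. "The series", "measured", "known", "first", "only" and "open" are said of these compounds alone.

In an ADME assay on CCRF-CEM cells (Homo sapiens) for antiproliferative activity, with a stated time of 48 h (a higher number here means a weaker inhibitor, a lower number a stronger inhibitor), compound 1 `C=C(Br)C(=O)Nc1ccc(/C=C/C(=O)c2cccc(OC)c2)cc1` gives 2300 nM and compound 2 `C=C(Br)C(=O)Nc1ccc(C(=O)/C=C/c2ccc(OC)cc2)cc1` gives 1100 nM while compound 3 `C=C(Br)C(=O)Nc1ccc(C(=O)/C=C/c2ccc(OC)c(OC)c2)cc1` gives 1600 nM as its measured number. Compound 3 stands within the scatter of both compound 1 and compound 2, so no rank can be given to it on these numbers.

The structural change leading to compound 4 `C=C(Br)C(=O)Nc1ccc(C(=O)/C=C/c2cc(OC)c(OC)c(OC)c2)cc1` is methoxy in place of hydrogen on an aromatic carbon and it amounts to methoxy in place of hydrogen on an aromatic carbon. Among the compounds with values here, only one measured step is of the same kind. That step is a 1.5-fold higher number from compound 2 to compound 3 (0.16 log units; within the scatter) and it stays within the scatter. It is a single precedent, and the new group has a different place on the ring, ortho to a methoxy group and meta to a methoxy group, so it offers only limited guidance. No change beyond the scatter is therefore expected in this assay and no direction can be favoured. The expected step is a 1.1-fold lower number from compound 3 to compound 4 (0.03 log units; within the scatter) on this reasoning. In this assay compound 4 is estimated at 1500 nM within an expected range (600 nM to 3500 nM).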

Compound 4, half-maximal inhibitory concentration: 330 nM
Beside the measured number, compound 4's estimate is 4.5-fold (0.66 log units) above it; measured number outside the range, below it.
By their numbers in this assay, from the lowest: compound 4; then compounds 2, 3 and 1 (each within the scatter of the next, the first and the last beyond it).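

In this assay, within the data shown here, methoxy in place of hydrogen, on an aromatic carbon ortho to a methoxy group and meta to a methoxy group, gives a 4.8-fold lower number from compound 3 to compound 4 (0.69 log units; beyond the scatter), the first step between two compounds differing in one place that lies beyond the scatter. The same exchange of hydrogen for methoxy at another place on this ring gives a 1.5-fold higher number from compound 2 to compound 3 (0.16 log units; within the scatter), which stays within the scatter, so within these two steps the outcome of the change depends on where the methoxy group enters or on the groups already on the ring. The data shown give no measured basis for explaining the larger step.

As far as these compounds go, it remains open whether this position calls specifically for methoxy, since a hydroxy group, a fluorine atom or an ethoxy group in the same place would show whether another substituent gives a step of similar size. From the compounds shown here alone, it also remains open whether the step needs both existing methoxy groups, a question that compounds carrying this third methoxy group with either of the other two replaced by hydrogen would address.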